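The source may hold more compounds than are shown below. What is called first, only, known or untested is meant among the compounds shown, and "the series" means these compounds.

Compound 1 `C[C@@H](O)[C@H]1C(=O)N2C(C(=O)OCC(F)(F)F)=C(S[C@@H]3CN[C@H](C(=O)Nc4cccc(C(=O)O)c4)C3)[C@H](C)[C@H]12` was tested in a physicochemical assay for metabolic stability, read by LC-MS, in phosphate buffer, with a stated time of 3 h, at pH 7.4, tested at 50 uM; on this read-out lower numbers stand for a less stable compound and higher numbers for a more stable compound. In this assay compound 1 gives > 95%, which is a limit of the assay rather than a number. Compound 2 `CC(C)OC(=O)c1cccc(NC(=O)[C@@H]2C[C@H](SC3=C(C(=O)O)N4C(=O)[C@H]([C@@H](C)O)[C@H]4[C@H]3C)CN2)c1` reaches the same limit, giving > 95% in this assay. Compound 3 `Cc1oc(=O)oc1COC(=O)N1C[C@@H]2C[C@H]1C(=O)Nc1cccc(c1)C(=O)OC/C=C\COC(=O)C1=C(S2)[C@H](C)[C@@H]2[C@@H]([C@@H](C)O)C(=O)N12` likewise sits at the limit, with > 95% in this assay. So every measured value stands at the limit of > 95% in this assay, at which 3 of the 3 values shown sit, and compound 1 cannot be placed above or below its companions on these numbers; all three share the same limit.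

Compound 4 `CC(C)OC(=O)C1=C(S[C@@H]2CN[C@H](C(=O)Nc3cccc(C(=O)O)c3)C2)[C@H](C)[C@@H]2[C@@H]([C@@H](C)O)C(=O)N12` has not yet been measured. It differs from compound 1 in one place: isopropyl in place of 2,2,2-trifluoroethyl on an oxygen next to a carbonyl group, which is isopropyl in place of 2,2,2-trifluoroethyl on an oxygen next to a carbonyl group. Among the measured compounds shown here, none of the measured compounds differ from one another in a single place, so no measured step can be used as a guide here.

Since every measured compound sits at the limit, no movement beyond the usual scatter is expected from compound 1 to compound 4, and the step is estimated at a step that the limit leaves unreadable from compound 1 to compound 4. For compound 4 the expected value in this assay is 96%, with a likely range from 88% to 100%.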

Compound 4, percent of the compound remaining: > 95%
Compound 4: a limit, no number (the forecaster's own chance of this, stated with the estimate: 80%); the middle value is on the limit's open side.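

No step can be read from compound 1 to compound 4 in this assay, because both compounds give a limit of the assay rather than a number: the limit of > 95% in this assay, at which 4 of the 4 values shown sit. The compounds shown leave open whether isopropyl in place of 2,2,2-trifluoroethyl on an oxygen next to a carbonyl group makes any difference to stability.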